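A few compounds are considered here, and "the series" means these few. Any claim that something is new, unique, unknown or untested is made for them only; others in the source may bear on it.

Three measured anilides and one unmeasured one share a core and are followed in a functional assay on A549 cells (Homo sapiens) for cytotoxicity, read by MTT assay, with a stated time of 72 h; a lower number here means a stronger inhibitor, a higher number a weaker inhibitor. Compound 1 `Cc1cc(=O)n(-c2ccccc2C(F)(F)F)nc1C(=O)Nc1ccc(Oc2ncnc3sccc23)cc1` gives 19900 nM. Compound 2 `Cc1cc(=O)n(-c2ccc(Br)cc2F)nc1C(=O)Nc1ccc(Oc2ncnc3sccc23)cc1` differs from compound 1 by 4-bromo-2-fluorophenyl in place of 2-(trifluoromethyl)phenyl on an aromatic nitrogen; in this assay compound 2 gives 12800 nM, a step of a 1.6-fold lower number from compound 1 to compound 2 (0.19 log units; within the scatter). Compound 3 `Cc1cc(=O)n(-c2ccccc2C(F)(F)F)nc1C(=O)Nc1ccc(Oc2ncnc3sccc23)c(F)c1` differs from compound 1 by fluoro in place of hydrogen on an aromatic carbon; in this assay compound 3 gives 16300 nM, a step of a 1.2-fold lower number from compound 1 to compound 3 (0.09 log units; within the scatter). Compound 2 and compound 3 are not compared directly; their two values lie within the scatter of each other. Compound 4 `Cc1cc(=O)n(-c2ccc(Br)cc2F)nc1C(=O)Nc1ccc(Oc2ncnc3sccc23)c(F)c1` is not yet measured and differs from compound 3 by 4-bromo-2-fluorophenyl in place of 2-(trifluoromethyl)phenyl on an aromatic nitrogen. Going by the values given here, the place around this change reads word for word as it does for the change from compound 1 to compound 2, so the two changes are taken as the same, made on two cores whose difference is the one given for compound 3. Among the compounds with values here, the step expected in this assay is a 1.6-fold lower number from compound 3 to compound 4 (0.19 log units; within the scatter), resting on the single earlier instance, a 1.6-fold lower number from compound 1 to compound 2 (0.19 log units; within the scatter), which lay within the scatter. For compound 4 the estimate is 10500 nM, with a range from 5000 nM to 22000 nM.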

Compound 4, half-maximal inhibitory concentration: 11500 nM
Beside the measured number, compound 4's estimate is 1.1-fold (0.04 log units) below it; the range from low to high includes it.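

In this assay, 4-bromo-2-fluorophenyl in place of 2-(trifluoromethyl)phenyl gives a 1.4-fold lower number from compound 3 to compound 4 (0.15 log units; within the scatter), and this agrees with the earlier instance of the change: the same change on two cores in this assay, a 1.6-fold lower number (0.19 log units; within the scatter) from compound 1 to compound 2 and a 1.4-fold lower number (0.15 log units; within the scatter) from compound 3 to compound 4, 1.1-fold (0.04 log units) apart, within the scatter of two such steps
Fluoro in place of hydrogen on an aromatic carbon gives a 1.1-fold lower number from compound 2 to compound 4 (0.05 log units; within the scatter), and this agrees in the same way: the same change on two cores in this assay, a 1.2-fold lower number (0.09 log units; within the scatter) from compound 1 to compound 3 and a 1.1-fold lower number (0.05 log units; within the scatter) from compound 2 to compound 4, 1.1-fold (0.04 log units) apart, within the scatter of two such steps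
Going by these compounds alone, both changes therefore carry from one core to the other without a detectable difference, but every step lies within the scatter, so this agreement is only between steps that cannot be told from no step at all, and it does not show that either change has a real effect that transfers.

On these data alone, it remains open whether a change with a step beyond the scatter would carry between these cores in the same way. An amine or a carboxylic acid on the aromatic ring in place of 4-bromo-2-fluorophenyl, or a longer chain in place of the methyl group, would be a further test of this.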